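Working notes: one methyl-to-hydrogen step, carried across the series

This account rests on a few compounds, and the source may have more. Where it says the series, first, only, none or still open, it means among the compounds named here.

Three compounds carry the same kind of spiro-fused core. Compound 1 `CC1OC2(C=CC(=O)C=C2)N(c2nc(-c3ccc4ccccc4c3)nn2-c2ccccc2)C1=O` and compound 2 `Cc1ccc(-n2nc(-c3ccc4ccccc4c3)nc2N2C(=O)C(C)OC23C=CC(=O)C=C3)cc1` differ only on the ring that bears the second nitrogen substituent. In a functional assay on A549 cells (Homo sapiens) for antiproliferative activity, with a stated time of 5 days (on this read-out lower numbers stand for stronger inhibition and higher numbers for weaker inhibition), compound 1 gives 310 nM and compound 2 gives 1210 nM. Compound 3 `Cc1ccc(-n2nc(-c3cccc4ccccc34)nc2N2C(=O)COC23C=CC(=O)C=C3)cc1` is the best measured so far: in this assay compound 3 gives 140 nM, which puts it beyond the scatter relative to both others.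

For the measured compounds named here, the one counted step is a 3.9-fold lower number from compound 2 to compound 1 (0.59 log units; beyond the scatter), where the structural change is hydrogen in place of methyl on an aromatic carbon. How the core of compound 3 differs from that of compound 2 is not broken down here; the two differ in more than one place.

Compound 4 `O=C1C=CC2(C=C1)OCC(=O)N2c1nc(-c2cccc3ccccc23)nn1-c1ccccc1` is not yet measured. It is derived from compound 3 by hydrogen in place of methyl on an aromatic carbon. The place description matches the earlier change word for word, so this is the same change on a different core. With only one prior occurrence the basis is thin, but it points one way, so a step of similar size is expected.

For compound 4, a step of a 2.8-fold lower number from compound 3 to compound 4 (0.45 log units; beyond the scatter) is expected because the matched step was a 3.9-fold lower number from compound 2 to compound 1 (0.59 log units; beyond the scatter) on the core of compound 1. On that basis compound 4 is estimated at 50 nM in this assay, with a plausible range from 18 nM to 140 nM.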

Compound 4, half-maximal inhibitory concentration: 80 nM
Compound 4: the middle estimate sits 1.6-fold (0.20 log units) below what was measured; low and high end bracket the measured number.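

In this assay, going from 4-methylphenyl to phenyl on the second core gives a 1.8-fold lower number from compound 3 to compound 4 (0.24 log units; within the scatter), so on this core alone the step cannot be told from repeat-measurement noise. Set beside the first occurrence, the two steps cannot be told apart in size: the same change on two cores in this assay, a 3.9-fold lower number (0.59 log units; beyond the scatter) from compound 2 to compound 1 and a 1.8-fold lower number (0.24 log units; within the scatter) from compound 3 to compound 4, 2.2-fold (0.35 log units) apart, within the scatter of two such steps. For the compounds shown here, the pair is compatible with the change carrying over from one core to the other, with the printed numbers falling the same way both times, but it does not show a fixed step size, since only one of the two steps lies beyond the scatter and two cores are a narrow basis for any rule about the series.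

The compounds shown have only methyl or hydrogen on this aromatic carbon, para to a large group, so the effect of an amine, a carboxylic acid or a longer chain in that place remains open. Going by these compounds alone, also open is which of the differences between the core of compound 1 and the core of compound 4 matters for the read-out, as those two compounds differ in more than one place and no single step connects them.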